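The source may hold more compounds than are shown below. What is called first, only, known or untested is meant among the compounds shown, and "the series" means these compounds.

Measured so far in a physicochemical assay for lipophilicity, using the shake flask method, measured as octanol-water partition, at pH 7.4; on this read-out higher numbers stand for higher lipophilicity and lower numbers for lower lipophilicity:
compound 1 `CCCCN(CCCC)CCCOc1ccc(C(=O)/C=C/c2ccccc2)cc1` 2.06
compound 2 `CCCN(CCC)CCCCOc1ccc(C(=O)/C=C/c2ccccc2)cc1` 1.95

Compound 2 has a single neighbour among the measured numbers; the step of a number 0.11 log units lower from compound 1 to compound 2 (within the scatter) lies within the scatter, so the two stand level in this assay. Compound 3 `CCCCN(CCCC)CCCCCOc1ccc(C(=O)/C=C/c2ccccc2)cc1` carries (dibutylamino)methyl in place of dipropylamino on a saturated chain carbon, four bonds along the chain from an oxygen on an aromatic ring. Within the data shown here, the one measured step bears on this change, and in the reverse sense: it too exchanged dibutylamino and dipropylamino, with the ether chain shortened rather than lengthened, and it was small. Compound 3 lengthens both the amine and the chain, so a rise beyond the scatter is expected, estimated as a number 0.55 log units higher from compound 2 to compound 3 (beyond the scatter). Compound 3 is thus expected near 2.5, between 2 and 3.1.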

Compound 3, partition coefficient: 2.14
Compound 3: the middle estimate sits 0.36 log units above what was measured; measured number inside the range.
By their numbers in this assay, from the lowest: compounds 2, 1 and 3 (each within the scatter of the next).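

In this assay, (dibutylamino)methyl in place of dipropylamino, on a saturated chain carbon, four bonds along the chain from an oxygen on an aromatic ring, gives a number 0.19 log units higher from compound 2 to compound 3 (within the scatter) and leaves the two compounds level. At this place, 10 heavy atoms against 7 in an open-chain amine substituent make no readable difference. No measurement available here explains this result.
Still open, going by these compounds, is whether a ring amine such as piperidine or morpholine, or a much longer chain, would move the number beyond the scatter.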